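Aryl-to-pyridyl swap on the propenyl chain of compound 1

The compounds below may be only part of what the source reports. "The series", "measured", "known", "first", "only" and "open" are said of these compounds alone.

Measured so far in a functional assay on HeLa cells (Homo sapiens) for cytotoxicity, read by WST assay, with a stated time of 48 h; a lower number here means a stronger inhibitor, a higher number a weaker inhibitor:
compound 1, `O[C@@H](c1ccccc1)[C@H]1CO[C@H](c2ccccc2)[C@@H](C/C=C/c2cccc(F)c2)C1`: 8380 nM
compound 2, `COc1ccc(/C=C/C[C@H]2C[C@@H]([C@@H](O)c3ccc(OC)c(OC)c3)CO[C@@H]2c2ccc(OC)c(OC)c2)cc1`: 12200 nM

For the measured compounds named here, compound 1 stands at the lowest of the two numbers in this assay, but the only other number, that of compound 2, lies within the scatter of it, so no order between compound 1 and compound 2 can be claimed. Going by the values given here, no pair of measured compounds differs in just one place, so no step is known.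

Compound 3, `O[C@@H](c1ccccc1)[C@H]1CO[C@H](c2ccccc2)[C@@H](C/C=C/c2cccnc2)C1`, is not yet measured. It differs from compound 1 by pyridin-3-yl in place of 3-fluorophenyl on a double-bonded chain carbon bound to a double-bonded chain carbon. Among the compounds with values here, with no measured step of this kind to lean on, the step is expected to be small, toward a higher number, and not beyond the scatter: a 1.4-fold higher number from compound 1 to compound 3 (0.16 log units; within the scatter) is the expected change from compound 1 to compound 3. Compound 3 is therefore estimated at 12000 nM, with a range from 4000 nM to 35000 nM.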

Compound 3, half-maximal inhibitory concentration: > 100000 nM
Compound 3 was reported as a limit (the forecaster's own chance of this, stated with the estimate: 15%); middle value at least 8.3-fold (0.92 log units) away from the limit.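

In this assay, pyridin-3-yl in place of 3-fluorophenyl on a double-bonded chain carbon bound to a double-bonded chain carbon gives an at least 11-fold higher number from compound 1 to compound 3 (1.07 log units; beyond the scatter). For the compounds shown here, this is the first step readable, and it shows that this position is not indifferent to the change of one six-membered aromatic ring for another, which compound 1 and compound 2, with values within the scatter of each other and no single-place difference, could not show. Compound 3 is reported only as a limit, so the step gives a bound and not a size: the limit of > 100000 nM in this assay, at which 1 of the 3 values shown sits.

Still open, from the compounds shown here alone, is whether the step follows the loss of the fluorine or the entry of the ring nitrogen, which a plain phenyl at this place would separate. Also open, going by these compounds, is how an amine or a carboxylic acid on this ring would read.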